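The source may report more compounds than this note shows. Statements on the series, on what has been measured and on what is new or still open speak of the compounds shown alone.

Of the compounds shown here, three have been measured in an ADME assay on microsomes from liver (Homo sapiens) for metabolic stability, with a stated time of 10 min; a higher number here means that more of the compound is left, a lower number that less of the compound is left. Compound 1 `CC(C)OC(=O)NCCS(=O)(=O)NC(=O)c1ccc(Nc2nc(NC3(c4ccc(Cl)cc4)CC3)nc(OCC(F)(F)F)n2)cc1` gives 100% in this assay. Compound 2 `CC(C)C(=O)NCCS(=O)(=O)NC(=O)c1ccc(Nc2nc(NC3(c4ccc(Cl)cc4)CC3)nc(OCC(F)(F)F)n2)cc1` gives 86% in this assay, and compound 3 `CNC(=O)NCCS(=O)(=O)NC(=O)c1ccc(Nc2nc(NC3(c4ccc(Cl)cc4)CC3)nc(OCC(F)(F)F)n2)cc1` gives 97% in this assay. Among the three numbers, compound 3 stands second highest: it sits close to compound 1, as a number 3 percentage points lower from compound 1 to compound 3 (within the scatter) shows, and clearly apart from compound 2, as a number 11 percentage points higher from compound 2 to compound 3 (beyond the scatter) shows. The remaining step, a number 14 percentage points lower from compound 1 to compound 2 (beyond the scatter), is also modest.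

Compound 4 `CC(C)(C)CNCCS(=O)(=O)NC(=O)c1ccc(Nc2nc(NC3(c4ccc(Cl)cc4)CC3)nc(OCC(F)(F)F)n2)cc1` is the next structure for this assay. It differs from compound 3 by neopentyl in place of methylcarbamoyl on an amine nitrogen. Among the compounds with values here, all three measured steps exchange one group on a carbonyl carbon; none of them removes the carbonyl, so no measured pair matches the change to compound 4. They bear on it only in showing that exchanges in this part of the structure have moved this assay by modest amounts, in a number 14 percentage points lower from compound 1 to compound 2 (beyond the scatter) and a number 11 percentage points higher from compound 2 to compound 3 (beyond the scatter), or not beyond the scatter, in a number 3 percentage points lower from compound 1 to compound 3 (within the scatter). A modest downward step, a number 11 percentage points lower from compound 3 to compound 4 (beyond the scatter), is therefore expected, with a wider range than the measured steps would suggest. Compound 4 is estimated at 86% in this assay, with a range from 65% to 100%.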

Compound 4, percent of the compound remaining: 89%
Compound 4: middle estimate off by 3 percentage points, on the low side; measured number inside the range.
By their numbers in this assay, from the lowest: compounds 2, 4, 3 and 1 (each within the scatter of the next, the first and the last beyond it).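

Within the data shown here, compound 4 is the first whose amine nitrogen carries a saturated chain instead of a carbonyl group, and in this assay this larger change gives a step no greater than those among the carbonyl groups. Against the two nearest carbonyl-bearing compounds the result stays inside the scatter (a number 8 percentage points lower from compound 3 to compound 4 (within the scatter); a number 3 percentage points higher from compound 2 to compound 4 (within the scatter)), so the departure of methylcarbamoyl, with its hydrogen-bond donor and acceptor, does not separate neopentyl from these groups in this read-out, and only the comparison with isopropoxycarbonyl passes the scatter, by a modest amount (a number 11 percentage points lower from compound 1 to compound 4 (beyond the scatter)). No measurement at hand accounts for the size of any of these steps.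

A methyl or ethyl group on this amine nitrogen would help separate the loss of the carbonyl from the size of neopentyl. As far as these compounds go, how a free primary amine, a cyclohexylmethyl group or a chain ending in a carboxylic acid would read at this place remains open, as does whether the closeness of these numbers would hold for such groups.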